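Swapping the aryl group on the ring nitrogen

The source may hold more compounds than are shown below. What is called first, only, known or untested is meant among the compounds shown, and "the series" means these compounds.

Compound 2 `COc1cc2c(Oc3ccc(NC(=O)c4cn(-c5ccccc5OC(F)(F)F)cn4)cc3F)ccnc2cc1OCCCN1CCCCC1` gives the lower of the two numbers measured in a functional assay on MKN-45 cells (Homo sapiens) for cytotoxicity, read by MTT assay, with a stated time of 72 h (on this read-out lower numbers stand for stronger inhibition and higher numbers for weaker inhibition), at 190 nM. Among the measured compounds shown here, compound 1 `COc1cc2c(Oc3ccc(NC(=O)c4cn(-c5cc(C)ccc5C)cn4)cc3F)ccnc2cc1OCCCN1CCN(C)CC1` gives 650 nM in this assay, a gap beyond the scatter; the two compounds differ in two places, so no single step links them. Compound 3 `COc1cc2c(Oc3ccc(NC(=O)c4cn(-c5cc(C)ccc5C)cn4)cc3F)ccnc2cc1OCCCN1CCCCC1` arises from compound 2 by 2,5-dimethylphenyl in place of 2-(trifluoromethoxy)phenyl on an aromatic nitrogen. For the measured compounds named here, no measured pair shows this change alone. Compound 1 carries the same 2,5-dimethylphenyl and gives 650 nM, which points towards a higher number. The expected step is a 2.0-fold higher number from compound 2 to compound 3 (0.30 log units; within the scatter). Compound 3 is estimated at 380 nM, within 130 nM to 1100 nM.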

Compound 3, half-maximal inhibitory concentration: 830 nM
Estimate against measurement, compound 3: 2.2-fold (0.34 log units) below, and the stated range covers the measured number.
By their numbers in this assay, from the lowest: compound 2; then compounds 1 and 3 (each within the scatter of the next).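

In this assay the aryl group on the aromatic nitrogen now has a step of its own: there is a 4.4-fold higher number from compound 2 to compound 3 (0.64 log units; beyond the scatter) when 2,5-dimethylphenyl replaces 2-(trifluoromethoxy)phenyl. The saturated chain end, by contrast, gives only a 1.3-fold higher number from compound 1 to compound 3 (0.11 log units; within the scatter) when piperidin-1-yl replaces 4-methylpiperazin-1-yl, so that swap is not resolved here. Nothing measured here accounts for either step.

The compounds shown leave open where an unsubstituted phenyl or a 2-methoxyphenyl on that nitrogen would fall. They also leave open whether 2-(trifluoromethoxy)phenyl keeps its standing alongside the 4-methylpiperazin-1-yl chain end.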